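A few compounds are considered here, and "the series" means these few. Any claim that something is new, unique, unknown or untested is made for them only; others in the source may bear on it.

Of the compounds shown here, three have been measured in a functional assay on MRC5 cells (Homo sapiens) for inhibition, read by microscopy and resazurin assay, with a stated time of 72 h; on this read-out lower numbers stand for stronger inhibition and higher numbers for weaker inhibition. Compound 1 `C=CCONC(=O)CN1C(=O)S/C(=C\c2cccc(C(=O)N[C@@H](CC(C)C)C(=O)OC)c2)C1=O` gives only a limit there, > 128000 nM. Compound 2 `COC(=O)[C@@H](NC(=O)c1cccc(/C=C2\SC(=O)N(CC(=O)NOCc3ccccc3)C2=O)c1)C(C)C` likewise stops at a limit, > 128000 nM. Compound 3 `C=CCONC(=O)Cn1cc(C(=O)NCC(=O)N[C@H](C(=O)O)C(C)C)c2ccccc21` also returns only a limit, > 128000 nM. No number was reached for any of them, so compound 3 cannot be ranked against the other two; the whole picture is the limit of > 128000 nM in this assay, at which 3 of the 3 values shown sit. Compound 4 `C=CCONC(=O)Cn1cc(C(=O)NCC(=O)N[C@@H](CC(C)C)C(=O)O)c2ccccc21` carries isobutyl in place of isopropyl on a saturated chain carbon bound to an amide-type nitrogen and a carbonyl carbon. Within the data shown here, no measured step exists to lean on, and compound 3 itself is a limit, so no change beyond the usual scatter is expected; the expected step is a step that the limit leaves unreadable from compound 3 to compound 4. Compound 4 is therefore expected at 200000 nM, with a range from 60000 nM to 600000 nM, most likely reported again only as a limit.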

Compound 4, half-maximal inhibitory concentration: > 128000 nM
Compound 4: a limit, no number; the forecaster's own chance of this, stated with the estimate: 90%; the middle value does not contradict the limit.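

Compound 3 and compound 4 both give only a limit in this assay, so no step can be read between them. The compounds shown leave open which structure, if any, would give an actual number, since everything sits at one limit: the limit of > 128000 nM in this assay, at which 4 of the 4 values shown sit.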